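The compounds below may be only part of what the source reports. "The series", "measured", "known", "first", "only" and "open" are said of these compounds alone.

Measured compounds:
compound 1 `CCCCC(C)n1ccc2cc(/C(C)=C/C(=O)Nc3ccccc3OCCCC(=O)O)ccc21` gives 6 nM
compound 2 `CCCCC(CC)n1ccc2cc(/C(C)=C/C(=O)Nc3ccccc3OCCCC(=O)O)ccc21` gives 7.1 nM
compound 3 `C/C(=C\C(=O)Nc1ccccc1OCCCC(=O)O)c1ccc2c(ccn2Cc2ccc(F)cc2)c1` gives 97 nM

All three numbers come from an assay on Prostate gland for inhibition of steroid 5-alpha-reductase (Rattus norvegicus); a lower number here means a stronger inhibitor, a higher number a weaker inhibitor. Compound 3 stands highest of the three: the step of a 16-fold higher number from compound 1 to compound 3 (1.21 log units; beyond the scatter) and the step of a 14-fold higher number from compound 2 to compound 3 (1.14 log units; beyond the scatter) are both large and beyond the scatter, whereas the step of a 1.2-fold higher number from compound 1 to compound 2 (0.07 log units; within the scatter) lies within the scatter.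

Compound 4 `COc1ccc(Cn2ccc3cc(/C(C)=C/C(=O)Nc4ccccc4OCCCC(=O)O)ccc32)cc1` is not yet measured in this assay. Compound 4 differs from compound 3 by methoxy in place of fluoro on an aromatic carbon. Going by the values given here, none of the measured steps bears directly on this change: the two large steps, from compound 1 and from compound 2 to compound 3, concern the exchange of a branched chain for the 4-fluorobenzyl group on the aromatic nitrogen, not what sits on the benzyl ring, and the small step between compound 1 and compound 2 concerns only the chain. With the benzyl group kept and only the group on its ring exchanged, no step beyond the scatter is expected in this assay from compound 3 to compound 4, that is a 1.0-fold higher number from compound 3 to compound 4 (0.01 log units; within the scatter). Compound 4 is therefore estimated at 100 nM, with a range from 40 nM to 250 nM.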

Compound 4, half-maximal inhibitory concentration: 480 nM
The estimate for compound 4 lay 4.8-fold (0.68 log units) below the measured number, outside the stated range (above it).
By their numbers in this assay, from the lowest: compounds 1 and 2 (each within the scatter of the next); then compound 3; then compound 4.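

The group on the benzyl ring matters in this assay: on the aromatic carbon para to a large group, methoxy in place of fluoro gives a 4.9-fold higher number from compound 3 to compound 4 (0.69 log units; beyond the scatter) and takes the series further from the branched-chain compounds. Against those chains, the 4-methoxybenzyl group gives a 68-fold higher number from compound 2 to compound 4 (1.83 log units; beyond the scatter) and an 80-fold higher number from compound 1 to compound 4 (1.90 log units; beyond the scatter), so the cost of a benzyl group on the aromatic nitrogen in this set depends on what its ring carries. No measurement available here accounts for the difference between fluoro and methoxy at this position.

The compounds shown leave open whether the oxygen of the methoxy group or just the larger group goes with the weaker inhibition. Methyl, hydroxyl or chloro at the same carbon, or unsubstituted benzyl, would help separate these readings.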